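A few compounds are considered here, and "the series" means these few. Any claim that something is new, unique, unknown or untested is made for them only; others in the source may bear on it.

In a functional assay on the whole organism (strain Hartley) for inhibition, with Cavia porcellus as the target, with stated times of 15 min and 2 min (on this read-out higher numbers stand for an effect only at larger amounts of compound and lower numbers for an effect already at smaller amounts), compound 1, `CCCCC1([C@H](O)/C=C/C2CCC(=O)[C@@H]2CCCCCC(=O)O)CCC1`, gives 0.032 mg/kg. Among the measured compounds shown here, of the two plain numbers obtained in this assay it holds the higher one; compound 3, `CCCCC1([C@@H](O)/C=C/C2CCC(=O)[C@@H]2CCCCCCC(=O)O)CCC1`, gives 0.0139 mg/kg, a lower number by a gap beyond the usual scatter, but compound 3 differs from compound 1 both at the carbon bearing the hydroxy group and in the acid chain, so no single step joins them. Compound 2, `CCCCC1([C@@H](O)/C=C/C2CCC(=O)[C@@H]2CCCCSCC(=O)OCC)CCC1`, gives only > 0.672 mg/kg, which is a limit of the assay and not a number. For the measured compounds named here, the sole measured step, an at least 48-fold lower number from compound 2 to compound 3 (1.68 log units; beyond the scatter), concerns a different change and rests on (the limit of > 0.672 mg/kg in this assay, at which 1 of the 3 values shown sits), so it says nothing about the acid chain by itself. Compound 4, `CCCCC1([C@H](O)/C=C/C2CCC(=O)[C@@H]2CCCCCCC(=O)O)CCC1`, is compound 1 with the change (carboxymethyl in place of carboxy on a saturated chain carbon, five bonds along the chain from a saturated ring carbon). Going by the values given here, no measured step isolates this exchange of carboxy for carboxymethyl, since compound 3 carries it together with the other configuration at the hydroxy-bearing carbon. The numbers of compound 1 and compound 3 hint, at most, at a modest move toward lower numbers, within or near the scatter. The expected step is a 1.6-fold lower number from compound 1 to compound 4 (0.20 log units; within the scatter). Compound 4 is therefore estimated at 0.02 mg/kg, with a range from 0.006 mg/kg to 0.07 mg/kg.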

Compound 4, dose for half-maximal effect: 0.0024 mg/kg
Compound 4: the middle estimate sits 8.3-fold (0.92 log units) above what was measured, outside the stated range (below it).
By their numbers in this assay, from the lowest: compound 4; then compound 3; then compound 1. At a limit, above all of these: compound 2.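

In this assay, among the compounds shown here, the exchange of carboxy for carboxymethyl on a saturated chain carbon, five bonds along the chain from a saturated ring carbon, gives a 13-fold lower number from compound 1 to compound 4 (1.12 log units; beyond the scatter), so this position responds strongly to that one added chain carbon, which the earlier compounds could not show because compound 3 carried the same chain with the opposite stereocentre. With the chain held the same, the stereocentre at a saturated chain carbon, drawn S in compound 3 and R in compound 4, also counts, with a 5.8-fold lower number from compound 3 to compound 4 (0.76 log units; beyond the scatter), and the drawn R form goes with the lowest number of the series. That second step needs one caution: the fact that one of compounds 3 and 4 is drawn with a defined configuration and the other without, at the place where they differ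

The compounds shown leave open whether the trend continues along the acid chain, for instance with a longer chain ending in a carboxylic acid, and whether the same stereocentre step holds on the shorter chain of compound 1. They also leave open whether the carboxylic acid at the chain end can give way to a primary amide or a hydroxymethyl group while the number stays this low.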